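The compounds below may be only part of what the source reports. "The series", "measured", "known", "first", "only" and "open" are said of these compounds alone.

Of the compounds shown here, three have been measured in a functional assay on JAR cells (Homo sapiens) for inhibition, read by MTT assay, with a stated time of 72 h; a lower number here means a stronger inhibitor, a higher number a weaker inhibitor. Compound 1 `CCOC(=O)C1=C(Nc2ccccc2)S/C(=C\c2cccc(C(=O)O)c2)C1=O` gives 11700 nM in this assay, and compound 2 `CCOC(=O)C1=C(Nc2ccccc2)S/C(=C\c2cc(OC)c(O)c(OC)c2)C1=O` gives 17400 nM. Compound 3 `CCOC(=O)C1=C(Nc2ccccc2Br)S/C(=C\c2ccc[nH]2)C1=O` gives 8900 nM in this assay, the lowest of the three numbers; its gap to compound 1 and its gap to compound 2 both lie within the usual scatter, so the three compounds cannot be ranked against each other on these values.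

Compound 4 `CCOC(=O)C1=C(Nc2cccc([N+](=O)[O-])c2)S/C(=C\c2ccc[nH]2)C1=O` has not yet been measured. It differs from compound 3 in one place: 3-nitrophenyl in place of 2-bromophenyl on an amine nitrogen. Among the measured compounds shown here, no measured pair in the set varies this position, so there is no step in this assay from which the size of the change can be read. Compound 4 is therefore expected to stay close to compound 3, with no step beyond the scatter in either direction, which is the step of a 1.1-fold higher number from compound 3 to compound 4 (0.05 log units; within the scatter) that the estimate means. Compound 4 is estimated to give 10000 nM in this assay, with a range from 3000 nM to 35000 nM.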

Compound 4, half-maximal inhibitory concentration: 10100 nM
For compound 4 the middle estimate is 1.0-fold (0.00 log units) below the measured one; the measured number falls inside the stated range.
By their numbers in this assay, from the lowest: compounds 3, 4, 1 and 2 (each within the scatter of the next).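

In this assay, among the compounds shown here, 3-nitrophenyl in place of 2-bromophenyl on the amine nitrogen gives a 1.1-fold higher number from compound 3 to compound 4 (0.05 log units; within the scatter), the first step that can be read at this position. The entering group has 9 heavy atoms and 2 hydrogen-bond acceptors, against 7 and 0 for the group it replaces, yet the two compounds stay within the scatter of each other. Nothing in the available data bears on why this exchange leaves the number within the scatter.

For the compounds shown here, compounds 1 and 2 carry an unsubstituted phenyl at this position but also differ from compound 3 and compound 4 elsewhere, so no step to them can be read. As far as these compounds go, it remains open how the unsubstituted phenyl would compare on the same core, and whether an amine or a carboxylic acid on the phenyl, or an ethyl chain in its place, would give a step beyond the scatter.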